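A few compounds are considered here, and "the series" means these few. Any claim that something is new, unique, unknown or untested is made for them only; others in the source may bear on it.

Measured compounds in an ADME assay on J774.1 cells (Mus musculus) for cytotoxicity, read by MTT assay, with a stated time of 48 h; on this read-out lower numbers stand for stronger inhibition and higher numbers for weaker inhibition:
compound 1, `CC(=O)Nc1ccc(/C=N/NC(=O)c2no[n+]([O-])c2C)cc1`: 235000 nM
compound 2, `Cc1c(C(=O)N/N=C/c2ccc(C(=O)O)cc2)no[n+]1[O-]`: > 300000 nM
compound 3, `Cc1c(/C=N/NC(=O)c2cnn(-c3ccccc3)c2)no[n+]1[O-]`: 295000 nM

Compound 2 stands at > 300000 nM in this assay, which is a limit of the assay and not a number. The relevant evidence is the limit of > 300000 nM in this assay, at which 1 of the 3 values shown sits. Compound 1 gives 235000 nM and compound 3 gives 295000 nM, both weak numbers. Compound 4, `Cc1c(C(=O)N/N=C/c2ccc(C(F)(F)F)cc2)no[n+]1[O-]`, differs from compound 2 by trifluoromethyl in place of carboxy on an aromatic carbon. Among the compounds with values here, the single measured step touching that position is an at least 1.2-fold higher number from compound 1 to compound 2 (0.10 log units; that floor lies within the scatter), a step within the scatter, and no measured step covers the trifluoromethyl group itself. The expectation is therefore a step in this assay no larger than the scatter, in no clear direction, with compound 4 remaining weak. Compound 4 is estimated at 280000 nM, range 120000 nM to 650000 nM. The expected step is an at least 1.0-fold lower number from compound 2 to compound 4 (0.02 log units; that floor lies within the scatter).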

Compound 4, half-maximal inhibitory concentration: > 400000 nM
Compound 4 gave a limit, no number; the forecaster's own chance of this, stated with the estimate: 45%; middle value at least 1.4-fold (0.15 log units) away from the limit.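

In this assay compound 4 gives > 400000 nM, a limit of the assay and not a number. Trifluoromethyl in place of acetamido gives an at least 1.7-fold higher number from compound 1 to compound 4 (0.23 log units; that floor lies within the scatter), and the step between the two limits, compound 2 and compound 4, cannot be read. At this position, para to a large group, a substituent with no hydrogen-bond donor or acceptor therefore ends at a limit just as carboxy does, so carboxy is not required for that outcome.

From the compounds shown here alone, what an amine or a longer chain would read at this position in this assay stays open. Going by these compounds, whether any group here gives a clearly lower number also stays open.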